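The source may hold more compounds than are shown below. What is called first, only, known or untested is meant among the compounds shown, and "the series" means these compounds.

In a functional assay on A-375 cells (Homo sapiens) for cytotoxicity, read by MTT assay (a higher number here means a weaker inhibitor, a lower number a stronger inhibitor), compound 1 (`CCCCC(=O)Oc1cc(/C=C/C(=O)c2ccc(OC)c3c2OC(C)(C)C=C3)ccc1OC`) gives 220 nM, compound 2 (`COc1ccc(/C=C/C(=O)c2ccc(OC)c3c2OC(C)(C)C=C3)cc1OC(=O)C1CC1`) gives 380 nM and compound 3 (`COc1ccc(/C=C/C(=O)c2ccc(OC)c3c2OC(C)(C)C=C3)cc1OC(=O)c1ccco1`) gives 680 nM. Going by the values given here, compound 3 has the highest of these numbers, but only one measured step clearly sets it apart, a 3.1-fold higher number from compound 1 to compound 3 (0.49 log units; beyond the scatter). By contrast, a 1.8-fold higher number from compound 2 to compound 3 (0.25 log units; within the scatter) and a 1.7-fold higher number from compound 1 to compound 2 (0.24 log units; within the scatter) remain small. Compound 4 (`COc1ccc(/C=C/C(=O)c2ccc(OC)c3c2OC(C)(C)C=C3)cc1CS(C)(=O)=O`) departs from compound 3 through ((methylsulfonyl)methyl in place of ((furan-2-yl)carbonyl)oxy on an aromatic carbon), with (methylsulfonyl)methyl in place of ((furan-2-yl)carbonyl)oxy on an aromatic carbon. Among the compounds with values here, the measured steps only exchange the group on a carbonyl carbon, so they are a loose guide, and no measured compound lacks that carbonyl. The expected change is a 1.2-fold higher number from compound 3 to compound 4 (0.07 log units; within the scatter), with no clear direction beyond the scatter. For compound 4 the estimated value is 800 nM, within an expected range of 200 nM to 3000 nM.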

Compound 4, half-maximal inhibitory concentration: > 10000 nM
Compound 4: no number, only a limit (the forecaster's own chance of this, stated with the estimate: 3%); middle value at least 12-fold (1.09 log units) away from the limit.
By their numbers in this assay, from the lowest: compounds 1, 2 and 3 (each within the scatter of the next, the first and the last beyond it). At a limit, above all of these: compound 4.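

In this assay compound 4 stands at a limit and not at a number: the limit of > 10000 nM in this assay, at which 1 of the 4 values shown sits. On this aromatic carbon, ortho to a methoxy group, the change is large against all three earlier compounds: an at least 14-fold higher number from compound 3 to compound 4 (1.16 log units; beyond the scatter), an at least 26-fold higher number from compound 2 to compound 4 (1.42 log units; beyond the scatter) and an at least 45-fold higher number from compound 1 to compound 4 (1.65 log units; beyond the scatter). Exchanges on the carbonyl carbon moved the numbers far less, so replacing the whole carbonyloxy group matters much more here than varying what it carries.

As far as these compounds go, how far compound 4 lies beyond its limit stays open. So does whether a simple amine or a carboxylic acid on this aromatic carbon would keep the numbers of compounds 1, 2 and 3.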